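Tetrazole in place of carbamoyl: outlook for compound 4

This account rests on a few compounds, and the source may have more. Where it says the series, first, only, none or still open, it means among the compounds named here.

Measured so far in an assay on isolated protein for inhibition of endoplasmic reticulum aminopeptidase 1 (Homo sapiens), with stated times of 15 min and 20 min; on this read-out lower numbers stand for stronger inhibition and higher numbers for weaker inhibition:
compound 1 `CCC(C)(NC(=O)c1cc(F)cc2cc(-c3ccc(C(F)(F)F)cc3)oc12)C(=O)O`: 2680 nM
compound 2 `COC(=O)C(C)(C)NC(=O)c1cc(F)cc2cc(-c3ccc(Cl)cc3)oc12`: > 10000 nM
compound 3 `CC(C)(NC(=O)c1cc(F)cc2cc(-c3ccc(Cl)cc3)oc12)C(N)=O`: > 10000 nM

Within the data shown here, compound 1 is the only member with a read number, giving 2680 nM in this assay. For compound 2 only a limit of the assay is known, > 10000 nM. Compound 3 likewise stands at a limit, > 10000 nM. The step that the two limits leave unreadable from compound 2 to compound 3 therefore cannot be sized, both values resting at the limit of > 10000 nM in this assay, at which 2 of the 3 values shown sit.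

Compound 4 `CC(C)(NC(=O)c1cc(F)cc2cc(-c3ccc(Cl)cc3)oc12)c1nnn[nH]1` differs from compound 3 by 1H-tetrazol-5-yl in place of carbamoyl on a saturated chain carbon bound to an amide-type nitrogen and two saturated chain carbons. Among the measured compounds shown here, no measured step covers this change, and compound 3 offers only a limit as starting point, so no direction can be read from the series. Compound 4 is expected near 4000 nM, in the range 800 nM to 20000 nM, an estimated step of an at least 2.5-fold lower number from compound 3 to compound 4 (0.39 log units; beyond the scatter) that remains uncertain because compound 3 sits at the limit of > 10000 nM in this assay, at which 2 of the 3 values shown sit.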

Compound 4, half-maximal inhibitory concentration: 275 nM
Beside the measured number, compound 4's estimate is 15-fold (1.16 log units) above it, outside the stated range (below it).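

Replacing carbamoyl with 1H-tetrazol-5-yl at this place gives an at least 36-fold lower number from compound 3 to compound 4 (1.56 log units; beyond the scatter), and replacing methoxycarbonyl gives an at least 36-fold lower number from compound 2 to compound 4 (1.56 log units; beyond the scatter). Among these compounds, this is the first change at this place that yields a readable step, and compound 4 gives a read number where neither earlier group did. Both steps are minimum sizes, as their starting compounds sit at the limit: the limit of > 10000 nM in this assay, at which 2 of the 4 values shown sit.

Compound 1 carries a carboxylic acid but differs from compound 4 in more than one place, so the two cannot be compared directly. On these data alone, how a carboxylic acid at this place on the core of compound 4 would read remains open.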